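This account rests on a few compounds, and the source may have more. Where it says the series, first, only, none or still open, it means among the compounds named here.

Compound 1 `COc1ccc2[nH]c(-c3ccccc3)c(C(c3c(-c4ccccc4)[nH]c4ccc(C)cc34)C3C(=O)NN=C3C)c2c1` is the starting point here. In a functional assay on HEp-2 cells (Homo sapiens) for cytotoxicity, read by MTT assay (on this read-out lower numbers stand for stronger inhibition and higher numbers for weaker inhibition), compound 1 gives 3500 nM. Compound 2 `CC1=NNC(=O)C1C(c1c(-c2ccccc2)[nH]c2ccccc12)c1c(-c2ccccc2)[nH]c2ccc(C)cc12` differs from it by hydrogen in place of methoxy on an aromatic carbon. For compound 2 this assay reports only a limit, > 100000 nM. That change made an at least 28-fold higher number from compound 1 to compound 2 (1.45 log units; beyond the scatter); the values shown reach (the limit of > 100000 nM in this assay, at which 1 of the 3 values shown sits). Compound 3 `COc1ccc2[nH]c(-c3ccccc3)c(C(c3c(-c4ccccc4)[nH]c4ccc(Cl)cc34)C3C(=O)NN=C3C)c2c1` differs from compound 1 by chloro in place of methyl on an aromatic carbon, and in this assay compound 3 gives 6200 nM; that step was a 1.8-fold higher number from compound 1 to compound 3 (0.25 log units; within the scatter). Compound 4 `CC1=NNC(=O)C1C(c1c(-c2ccccc2)[nH]c2ccccc12)c1c(-c2ccccc2)[nH]c2ccc(Cl)cc12` has not yet been measured. For the measured compounds named here, it differs from compound 3 by hydrogen in place of methoxy on an aromatic carbon, which is the same change as the one that led from compound 1 to compound 2. Since that change made an at least 28-fold higher number from compound 1 to compound 2 (1.45 log units; beyond the scatter), and the cores of compound 3 and compound 1 differ only by chloro in place of methyl on an aromatic carbon, a step of about a 27-fold higher number from compound 3 to compound 4 (1.44 log units; beyond the scatter) is expected from compound 3 to compound 4 in this assay. For compound 4 a value around 170000 nM is therefore estimated, most likely reported only as a limit, with a range from 40000 nM to 600000 nM.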

Compound 4, half-maximal inhibitory concentration: 41700 nM
Compound 4: middle estimate off by 4.1-fold (0.61 log units), on the high side; the measured number falls inside the stated range.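

Hydrogen in place of methoxy again gave a 6.7-fold higher number from compound 3 to compound 4 (0.83 log units; beyond the scatter) in this assay, so the direction of the change carried over from the methyl-bearing compounds to the chloro-bearing ones, but its size did not: the same change on two cores in this assay, an at least 28-fold higher number (1.45 log units; beyond the scatter) from compound 1 to compound 2 and a 6.7-fold higher number (0.83 log units; beyond the scatter) from compound 3 to compound 4, at least 4.2-fold (0.62 log units) apart, beyond the scatter of two such steps. Chloro in place of methyl also behaved differently on the two cores, giving an at least 2.3-fold lower number from compound 2 to compound 4 (0.37 log units; beyond the scatter), whereas the same swap with methoxy present stayed within the scatter: the same change on two cores in this assay, a 1.8-fold higher number (0.25 log units; within the scatter) from compound 1 to compound 3 and an at least 2.3-fold lower number (0.37 log units; beyond the scatter) from compound 2 to compound 4, at least 4.2-fold (0.62 log units) apart, beyond the scatter of two such steps. As far as these compounds go, compound 2 is reported only as a limit, > 100000 nM, so the true size of its step stays unknown, and these two pairs show no rule for the wider series.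

The compounds shown leave open how an ethoxy group, a hydroxyl group or an amine would compare with methoxy on the same aromatic carbon. They also leave open whether a bromo or trifluoromethyl group in place of chloro would follow the same pattern on these two cores.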